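Arylpiperazine amides: benzisoxazole-type replacement on the piperazine nitrogen

A few compounds are considered here, and "the series" means these few. Any claim that something is new, unique, unknown or untested is made for them only; others in the source may bear on it.

Measured compounds:
- compound 1 `COc1ccccc1N1CCN(CCCCC(=O)N2Cc3ccccc3C[C@H]2C(N)=O)CC1`: 551 nM
- compound 2 `NC(=O)[C@@H]1Cc2ccccc2CN1C(=O)CCCCCN1CCN(c2ccccc2Cl)CC1`: 393 nM

Both compounds were tested in an assay on HEK293 cells for displacement of a labelled ligand from 5-hydroxytryptamine receptor 7 (Homo sapiens), with a stated time of 1 h; on this read-out lower numbers stand for stronger inhibition and higher numbers for weaker inhibition. In this assay compound 1 gives 551 nM and compound 2 gives 393 nM. The two numbers lie within the usual scatter of each other, so compound 2 cannot be set apart from compound 1 on this read-out; the pair only shows that an aryl group on the distal piperazine nitrogen of this core lands in the sub-micromolar range in this assay.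

Compound 3 `NC(=O)[C@@H]1Cc2ccccc2CN1C(=O)CCCCCN1CCN(c2noc3ccccc23)CC1` is not yet measured. It differs from compound 2 in one place: a group of 9 heavy atoms (7 carbon, 1 nitrogen, 1 oxygen; one five-membered aromatic ring with 2 hetero atoms, one six-membered aromatic ring of carbon only) in place of a group of 7 heavy atoms (6 carbon, 1 chlorine; one six-membered aromatic ring of carbon only), on an amine nitrogen in a ring. Going by the values given here, no measured pair shows this change, so the size of the step cannot be read from the data. The entering group keeps one six-membered carbon ring and adds a five-membered ring with two hetero atoms and two acceptors; the expectation is a modest gain rather than a loss, though a step within the scatter is fully possible.

Compound 3 is expected to give 150 nM in this assay, with a range of 35 nM to 700 nM. This estimate means an expected step of a 2.6-fold lower number from compound 2 to compound 3 (0.42 log units; beyond the scatter).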

Compound 3, inhibition constant: 22 nM
Compound 3: middle estimate off by 6.8-fold (0.83 log units), on the high side; measured number below the stated range.
By their numbers in this assay, from the lowest: compound 3; then compounds 2 and 1 (each within the scatter of the next).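

In this assay, the group on the amine nitrogen of the piperazine ring turns out to carry much of the weight: 2-chlorophenyl giving way to the two-ring group with a five-membered aromatic ring bearing 2 hetero atoms gives an 18-fold lower number from compound 2 to compound 3 (1.25 log units; beyond the scatter), a large step well beyond the scatter. Compound 1 and compound 2 could not show this, as they lie within the scatter of each other and differ in more than one place, whereas this single change shows that the position can move the number strongly while the rest of the structure stays fixed. Nothing available on this series accounts for the size of the step, so it stands as an observation only.

Still open, from the compounds shown here alone, is whether the gain belongs to the two-ring group as a whole or to its hetero atoms, a question that a naphthyl group or an unsubstituted phenyl on the same nitrogen would help to separate. Also open, going by these compounds, is whether the two-ring group keeps its effect on the chain of compound 1, or on a longer chain.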